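The source may hold more compounds than are shown below. What is called first, only, known or untested is meant among the compounds shown, and "the series" means these compounds.

Compound 1 `Cn1c(-c2cccnc2)c(CCC(=O)N2CCC(O)(Cc3ccccc3)CC2)c2cc(Cl)ccc21` in an assay on CHO cells for displacement of a labelled ligand from Substance-P receptor (Homo sapiens) (on this read-out lower numbers stand for stronger inhibition and higher numbers for weaker inhibition), gives 0.92 nM. Going by the values given here, compound 2 `Cn1c(-c2ccccn2)c(CCC(=O)N2CCC(O)(Cc3ccccc3)CC2)c2cc(Cl)ccc21` in this assay gives 2.9 nM; the step of a 3.2-fold higher number from compound 1 to compound 2 (0.50 log units; beyond the scatter) is the only comparison available within the pair, and it leaves compound 2 standing at the higher of the two numbers, with compound 1 as its nearest neighbour at the lower one.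

Compound 3 `Cn1c(-c2ccc(C(F)(F)F)cn2)c(CCC(=O)N2CCC(O)(Cc3ccccc3)CC2)c2cc(Cl)ccc21` differs from compound 2 by trifluoromethyl in place of hydrogen on an aromatic carbon. Among the compounds with values here, no measured step touches a trifluoromethyl group or any substituent on the pyridin-2-yl ring; the only step measured, a 3.2-fold higher number from compound 1 to compound 2 (0.50 log units; beyond the scatter), concerns the attachment point of the pyridine ring and says nothing about what a substituent on that ring does. The expectation for compound 3 therefore rests on compound 2 alone, and with nothing to point in either direction the expected step of a 1.2-fold higher number from compound 2 to compound 3 (0.08 log units; within the scatter) is taken as none beyond the scatter, with a wide range to cover a modest move either way. Compound 3 is estimated at 3.5 nM in this assay, with a range from 1 nM to 12 nM.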

Compound 3, half-maximal inhibitory concentration: 0.12 nM
For compound 3 the middle estimate is 29-fold (1.46 log units) above the measured one; the measured number lies below the stated range.
By their numbers in this assay, from the lowest: compound 3; then compound 1; then compound 2.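

In this assay, going by these compounds alone, the ring carbon two atoms from the ring nitrogen, para to a large group, turns out to be highly responsive: trifluoromethyl in place of hydrogen there gives a 24-fold lower number from compound 2 to compound 3 (1.38 log units; beyond the scatter) and is a large step, whereas the only earlier step, a 3.2-fold higher number from compound 1 to compound 2 (0.50 log units; beyond the scatter) for the change of attachment point, was modest and went the other way. The substituent more than makes up that earlier loss, since 5-(trifluoromethyl)pyridin-2-yl in place of pyridin-3-yl gives a 7.7-fold lower number from compound 1 to compound 3 (0.88 log units; beyond the scatter) and leaves compound 3 with the lowest number of the three, both of its steps lying beyond the scatter. Nothing available accounts for the size of this gain.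

As far as these compounds go, whether the gain is particular to trifluoromethyl or would also appear with a chlorine, a methyl, a methoxy or a nitrile on the same carbon remains open. Also open, from the compounds shown here alone, are whether trifluoromethyl on the pyridin-3-yl ring of compound 1 would give a step of similar size, and whether other carbons of the pyridine ring respond in the same way.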